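N-Methylation of the Amide in a Clearance Series

The compounds below may be only part of what the source reports. "The series", "measured", "known", "first", "only" and "open" are said of these compounds alone.

Compound 2 `Cc1cn(C)nc1[C@H](C)Nc1c(C(N)=O)nnc2ccc(-c3ccc(OCCCN(C)C)nc3)cc12` and compound 1 `C[C@H](Nc1c(C(N)=O)nnc2ccc(-c3ccc(OCCCN(C)C)nc3)cc12)c1ccn(C)n1` were both examined in an ADME assay on microsomes from liver (Homo sapiens) for metabolic stability, read by LC-MS, using NADPH, with a stated time of 30 min, tested at 1 uM; a higher number here means faster removal of the compound, a lower number slower removal. Compound 1 gives 10 mL.min-1.g-1 in this assay, and compound 2 gives 27 mL.min-1.g-1. Among the compounds with values here, the one measured step in the set, a 2.7-fold higher number from compound 1 to compound 2 (0.43 log units; beyond the scatter), therefore leaves compound 2 with the higher of the two numbers. Compound 3 `CNC(=O)c1nnc2ccc(-c3ccc(OCCCN(C)C)nc3)cc2c1N[C@@H](C)c1nn(C)cc1C` has not yet been measured. It differs from compound 2 in one place: methyl in place of hydrogen on an amide-type nitrogen, the methyl sitting on an amide-type nitrogen whose other neighbour is a carbonyl carbon, so that the carbamoyl group becomes a methylcarbamoyl group. Within the data shown here, the only measured step concerns a methyl added on an aromatic carbon, a different place from the one changed here, so it bears on the new step only as a general sign that adding a methyl moved the number upward by a modest margin. On that basis a small rise, or none beyond the scatter, is expected in this assay for compound 3, as a 1.3-fold higher number from compound 2 to compound 3 (0.11 log units; within the scatter). Compound 3 is estimated at 35 mL.min-1.g-1, with a range from 15 mL.min-1.g-1 to 80 mL.min-1.g-1.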

Compound 3, intrinsic clearance in microsomes: 33 mL.min-1.g-1
For compound 3 the middle estimate is 1.1-fold (0.03 log units) above the measured one, within the range that was stated.
By their numbers in this assay, from the lowest: compound 1; then compounds 2 and 3 (each within the scatter of the next).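

In this assay, methyl in place of hydrogen on the amide-type nitrogen, which turns the carbamoyl group of compound 2 into the methylcarbamoyl group of compound 3, gives a 1.2-fold higher number from compound 2 to compound 3 (0.09 log units; within the scatter) and so leaves the number unchanged within the scatter. The earlier compounds shown here showed only a methyl on an aromatic carbon, where a 2.7-fold higher number from compound 1 to compound 2 (0.43 log units; beyond the scatter) lay beyond the scatter; the two compounds now show that a methyl does not move the number at every place, and that the amide hydrogen of compound 2 can be replaced at this nitrogen with no measurable change in this read-out. Nothing at hand says why the number holds at this nitrogen when it moved at the aromatic carbon.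

The compounds shown leave open whether a larger group on the same nitrogen, such as ethyl or cyclopropyl, or a second methyl giving a dimethylcarbamoyl group, would also leave the number in place. They also leave open whether a carboxylic acid or a nitrile in place of the carbamoyl group would change the number in this assay by more than the scatter.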